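The source may hold more compounds than are shown below. What is called first, only, known or untested is meant among the compounds shown, and "the series" means these compounds.

Compound 1 `C=C/C=C\[C@H](C)[C@H](OC(N)=O)[C@@H](C)[C@H](OC(C)=O)[C@@H](C)C/C(C)=C\[C@H](C)[C@@H](OC(C)=O)[C@@H](C)/C=C\[C@H](C[C@@H]1OC(=O)[C@H](C)[C@@H](OC(C)=O)[C@H]1C)OC(C)=O` in a functional assay on P388 cells (Mus musculus) for cytotoxicity, read by MTT assay, with a stated time of 48 h (on this read-out lower numbers stand for stronger inhibition and higher numbers for weaker inhibition), gives 837 nM. Compound 2 `C=C/C=C\[C@H](C)[C@H](OC(N)=O)[C@@H](C)[C@H](OC(C)=O)[C@@H](C)C/C(C)=C\[C@H](C)[C@@H](O)[C@@H](C)/C=C\[C@H](C[C@@H]1OC(=O)[C@H](C)[C@@H](OC(C)=O)[C@H]1C)OC(C)=O` gives only > 6920 nM, which is a limit of the assay and not a number, and it sits at the limit of > 6920 nM in this assay, at which 1 of the 3 values shown sits. Compound 3 `C=C/C=C\[C@H](C)[C@H](OC(N)=O)[C@@H](C)[C@H](O)[C@@H](C)C/C(C)=C\[C@H](C)[C@@H](OC(C)=O)[C@@H](C)/C=C\[C@H](C[C@@H]1OC(=O)[C@H](C)[C@@H](OC(C)=O)[C@H]1C)OC(C)=O` in this assay gives 166 nM. Compound 4 `C=C/C=C\[C@H](C)[C@H](OC(N)=O)[C@@H](C)[C@H](O)[C@@H](C)C/C(C)=C\[C@H](C)[C@@H](O)[C@@H](C)/C=C\[C@H](C[C@@H]1OC(=O)[C@H](C)[C@@H](OC(C)=O)[C@H]1C)OC(C)=O` is not yet measured; it differs from compound 2 by hydrogen in place of acetyl on an oxygen on a saturated carbon. Among the compounds with values here, two measured steps bear on this change: removing one acetyl gave an at least 8.2-fold higher number from compound 1 to compound 2 (0.91 log units; beyond the scatter), while removing the other acetyl, the one compound 4 now loses, gave a 5.0-fold lower number from compound 1 to compound 3 (0.70 log units; beyond the scatter). A lowering of roughly that size is therefore expected in this assay, although, starting from a limit, the result may itself remain a limit. Compound 4 is estimated at 4000 nM, between 1000 nM and 20000 nM. The expected step is an at least 1.7-fold lower number from compound 2 to compound 4 (0.23 log units; that floor lies within the scatter).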

Compound 4, half-maximal inhibitory concentration: 0.74 nM
The estimate for compound 4 lay 5400-fold (3.73 log units) above the measured number; measured number below the stated range.
By their numbers in this assay, from the lowest: compound 4; then compound 3; then compound 1. At a limit, above all of these: compound 2.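

In this assay, removing both acetyl groups together goes much further than either removal alone suggested, with an at least 9300-fold lower number from compound 2 to compound 4 (3.97 log units; beyond the scatter) and a 220-fold lower number from compound 3 to compound 4 (2.35 log units; beyond the scatter). One acetoxy to hydroxy change raises the number on the core of compound 1 but lowers it once the other acetyl has gone: the same change on two cores in this assay, an at least 8.2-fold higher number (0.91 log units; beyond the scatter) from compound 1 to compound 2 and a 220-fold lower number (2.35 log units; beyond the scatter) from compound 3 to compound 4, at least 1800-fold (3.26 log units) apart, beyond the scatter of two such steps. The size of the other change likewise depends on the core that carries it: the same change on two cores in this assay, a 5.0-fold lower number (0.70 log units; beyond the scatter) from compound 1 to compound 3 and an at least 9300-fold lower number (3.97 log units; beyond the scatter) from compound 2 to compound 4, at least 1800-fold (3.26 log units) apart, beyond the scatter of two such steps. The compounds shown leave open whether a methoxy group at these places would act like hydroxy. They also leave open what the acetyl groups remaining on compound 4 contribute.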